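A Furan Replaces Isopropyl Where Three Limits Already Sit

This account rests on a few compounds, and the source may have more. Where it says the series, first, only, none or still open, it means among the compounds named here.

Three compounds share one core and differ only in the group carried on a saturated chain carbon bound to an amine nitrogen in a ring. Compound 1 `Cc1ccc2c(NCc3ccc(NC(=O)C4CCN(Cc5ccc(Cl)cc5)CC4)cc3)nc(N(C)C)nc2c1` carries 4-chlorophenyl there. In a functional assay on SV5A8 cells (Homo sapiens) for cytotoxicity (a lower number here means a stronger inhibitor, a higher number a weaker inhibitor), compound 1 reaches only a limit of the assay, > 3180 nM. Compound 2 `Cc1ccc2c(NCc3ccc(NC(=O)C4CCN(Cc5ncc[nH]5)CC4)cc3)nc(N(C)C)nc2c1` carries 1H-imidazol-2-yl, and in this assay compound 2 likewise gives only a limit, > 20000 nM. Compound 3 `Cc1ccc2c(NCc3ccc(NC(=O)C4CCN(CC(C)C)CC4)cc3)nc(N(C)C)nc2c1` carries isopropyl, and in this assay compound 3 also stops at a limit, > 10500 nM. Every one of these values is a limit. None of the steps between them can be read: a step that the two limits leave unreadable from compound 1 to compound 2, a step that the two limits leave unreadable from compound 1 to compound 3 and a step that the two limits leave unreadable from compound 2 to compound 3.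

Compound 4 `Cc1ccc2c(NCc3ccc(NC(=O)C4CCN(Cc5ccco5)CC4)cc3)nc(N(C)C)nc2c1` is not yet measured. Its change from compound 3 is furan-2-yl in place of isopropyl on a saturated chain carbon bound to an amine nitrogen in a ring. The three measured steps all concern the same place, and each was unreadable, so they give no direction for this one. With 4-chlorophenyl, 1H-imidazol-2-yl and isopropyl all ending at a limit, furan-2-yl at the same place is expected to end the same way. Compound 4 is therefore expected to give 15000 nM in this assay, within 4000 nM to 60000 nM, most probably reported as a limit once more. The expected step is a step that the limit leaves unreadable from compound 3 to compound 4.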

Compound 4, half-maximal inhibitory concentration: > 20000 nM
Compound 4 was reported as a limit; the forecaster's own chance of this, stated with the estimate: 80%; at least 1.3-fold (0.12 log units) between middle value and limit.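

Within the data shown here, compound 4 ends at a limit in this assay, as compounds 1, 2 and 3 do, so no step between compound 4 and any of those three can be read. Compound 4 shares its limit with compound 2: the limit of > 20000 nM in this assay, at which 2 of the 4 values shown sit. The compounds shown leave open whether these four groups differ in this read-out at all.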